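The compounds below may be only part of what the source reports. "The series", "measured", "known", "first", "only" and "open" are said of these compounds alone.

Measured in a functional assay on MCF7 cells (Homo sapiens) for antiproliferative activity, read by MTT assay, with a stated time of 24 h; a lower number here means a stronger inhibitor, a higher number a weaker inhibitor:
- compound 1 `CCCCc1oc2ccccc2c1C(=O)c1ccc(OCC(=O)N2CCCC2)cc1`: 42400 nM
- compound 2 `CCCCc1oc2ccccc2c1C(=O)c1ccc(OCC(=O)N2CCOCC2)cc1`: 34000 nM

Among the compounds with values here, compound 1 is not separated from its only measured neighbour, with a 1.2-fold lower number from compound 1 to compound 2 (0.10 log units; within the scatter). Compound 3 `CCCCc1oc2ccccc2c1C(=O)c1ccc(OCC(=O)N[C@H](C)c2ccccc2)cc1` brings a larger change at the same place: (1-phenylethyl)amino in place of pyrrolidin-1-yl on a carbonyl carbon. Within the data shown here, the morpholin-4-yl exchange is the only measured step there, and it stayed within the scatter. It added no hydrogen-bond donor and no six-membered aromatic ring of carbon only, so it offers limited guidance. In this assay, only a modest move to a lower number is expected, which may not clear the scatter. The expected step is a 1.5-fold lower number from compound 1 to compound 3 (0.18 log units; within the scatter). For compound 3 the estimated value is 28000 nM, with an expected range of 10000 nM to 70000 nM.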

Compound 3, half-maximal inhibitory concentration: 14100 nM
Estimate against measurement, compound 3: 2.0-fold (0.30 log units) above, within the range that was stated.
By their numbers in this assay, from the lowest: compound 3; then compounds 2 and 1 (each within the scatter of the next).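

In this assay the place on the carbonyl carbon now responds to a change: (1-phenylethyl)amino gives two steps beyond the scatter (a 3.0-fold lower number from compound 1 to compound 3 (0.48 log units; beyond the scatter); a 2.4-fold lower number from compound 2 to compound 3 (0.38 log units; beyond the scatter)), whereas morpholin-4-yl and pyrrolidin-1-yl remained inseparable. The entering group brings a six-membered aromatic ring of carbon only, a hydrogen-bond donor and a defined stereocentre together, so these compounds cannot assign the step to any one feature. No evidence on the origin of the step is available.

Open, from the compounds shown here alone, is whether benzylamino, lacking the methyl branch, would retain the lower number. The opposite enantiomer of (1-phenylethyl)amino leaves the same question for the stereocentre.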